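The source may hold more compounds than are shown below. What is called first, only, known or untested is meant among the compounds shown, and "the series" means these compounds.

For the measured compounds named here, in a functional assay on SF-295 cells (Homo sapiens) for antiproliferative activity (on this read-out lower numbers stand for stronger inhibition of growth and higher numbers for weaker inhibition of growth), compound 1 (`Oc1cc(-c2ccc3ccccc3c2)nc2ncccc12`) gives 9120 nM, the highest of the three numbers measured so far. Compound 2 (`Cc1ccnc2nc(-c3cccc4ccccc34)cc(O)c12`) reaches 10.7 nM and compound 3 (`Cc1cc(C)c2c(O)cc(-c3cccc(F)c3)nc2n1`) reaches 33.1 nM, both far lower and beyond the scatter. Compound 4 (`Cc1ccnc2nc(-c3ccc4ccccc4c3)cc(O)c12`) has not yet been measured. It departs from compound 1 by one change, methyl in place of hydrogen on an aromatic carbon. Going by the values given here, no step between measured compounds isolates this change. Compound 2 and compound 3 both carry methyl on the core, but each also differs from compound 4 in its other substituents, so they offer only indirect support. On that evidence, a large fall in the number is expected, well beyond the scatter, though compound 4 is not expected to match compound 2 fully. The expected step is a 30-fold lower number from compound 1 to compound 4 (1.48 log units; beyond the scatter). For compound 4 the estimated value in this assay is 300 nM, with an expected range of 40 nM to 2500 nM.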

Compound 4, concentration for 50% growth inhibition: 1480 nM
Beside the measured number, compound 4's estimate is 4.9-fold (0.69 log units) below it; the range from low to high includes it.
By their numbers in this assay, from the lowest: compound 2; then compound 3; then compound 4; then compound 1.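

In this assay, for the compounds shown here, this is the first direct reading of methyl in place of hydrogen on an aromatic carbon, and it gives a 6.2-fold lower number from compound 1 to compound 4 (0.79 log units; beyond the scatter). The earlier compounds shown here carried methyl only alongside other differences, whereas this pair shows that the single added carbon, ortho to a fused ring and opposite the ring nitrogen, lowers the number on its own, though compound 4 still stands at 1480 nM. Nothing measured here speaks to why the number falls at this position.

The compounds shown leave open whether an ethyl group, a methoxy group or an amine at this same position would lower the number further, match methyl or reverse the step. This single pair also leaves open whether methyl gives a step of similar size when the other substituents on the core are changed.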